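Swapping 1H-benzimidazol-2-yl for pyrimidin-2-yl in the series

The source may report more compounds than this note shows. Statements on the series, on what has been measured and on what is new or still open speak of the compounds shown alone.

In an ADME assay for permeability, using PAMPA, with a stated time of 4 h, at pH 7.4 (on this read-out lower numbers stand for lower permeability and higher numbers for higher permeability), compound 1 (`c1cnc2c(c1)CN[C@@H](CN(CCCN1CCNCC1)[C@H]1CCCc3cccnc31)C2`) gives 9 nm/s and compound 2 (`c1cnc2c(c1)CCC[C@@H]2N(CCCN1CCNCC1)Cc1nc2ccccc2[nH]1`) gives 146 nm/s, so compound 2 holds the higher of the two numbers. The next structure, compound 3 (`c1cnc(CN(CCCN2CCNCC2)[C@H]2CCCc3cccnc32)nc1`), departs from compound 2 by pyrimidin-2-yl in place of 1H-benzimidazol-2-yl on a saturated chain carbon bound to an amine nitrogen: pyrimidin-2-yl in place of 1H-benzimidazol-2-yl, on a saturated chain carbon bound to an amine nitrogen.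

Among the compounds with values here, only one measured step bears on this change: a 16-fold higher number from compound 1 to compound 2 (1.21 log units; beyond the scatter). It is large and beyond the scatter, and it falls at the same place. It brought 1H-benzimidazol-2-yl in, but it says nothing direct about pyrimidin-2-yl, for which no measurement exists yet. That step shows only how far a change at this place can move the read-out, so it is a loose guide to size. A move to a lower number is expected, though a smaller one than that step: a 2.9-fold lower number from compound 2 to compound 3 (0.47 log units; beyond the scatter) is the estimated change. For compound 3 the estimate in this assay is 50 nm/s, with an expected range of 12 nm/s to 200 nm/s.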

Compound 3, apparent permeability: 31 nm/s
Compound 3: the middle estimate sits 1.6-fold (0.21 log units) above what was measured, and the stated range covers the measured number.
By their numbers in this assay, from the lowest: compound 1; then compound 3; then compound 2.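

In this assay, within the data shown here, pyrimidin-2-yl gives the first reading for a monocyclic aromatic group at this place, on a saturated chain carbon bound to an amine nitrogen, with a 4.7-fold lower number from compound 2 to compound 3 (0.67 log units; beyond the scatter) and a 3.4-fold higher number from compound 1 to compound 3 (0.54 log units; beyond the scatter); the read-out therefore responds to this change, though less strongly than to the earlier change at the same place. Among the three compounds, the order does not follow the heavy-atom count of the group: compound 2 gives the highest number, compound 3, with the fewest heavy atoms in the group, the middle one, and compound 1, with the most, the lowest. The change from compound 2 to compound 3 alters the ring count, the hydrogen-bond donors and the hydrogen-bond acceptors together, and no measurement here offers an explanation for the shift.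

Which of these differences carries the step stays open; 1-methyl-1H-benzimidazol-2-yl and 1H-imidazol-2-yl at the same place would help separate them. Also open, as far as these compounds go, is whether the same order of groups would persist with a longer chain on the amine nitrogen.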